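Swapping 3-Nitrophenyl for 3,4,5-Trimethoxyphenyl: An Expected Flat Step

The source may report more compounds than this note shows. Statements on the series, on what has been measured and on what is new or still open speak of the compounds shown alone.

Of the compounds shown here, three sharing one core have been measured in an ADME assay on L02 cells (Homo sapiens) for cytotoxicity, read by MTT assay, with a stated time of 24 h; a higher number here means a weaker inhibitor, a lower number a stronger inhibitor. Compound 1 `O=C1/C(=C/c2cccc([N+](=O)[O-])c2)CN(S(=O)(=O)c2ccc(F)cc2)C/C1=C\c1cccc([N+](=O)[O-])c1` gives 15500 nM. Compound 2 `COc1cc(/C=C2\CN(S(=O)(=O)c3ccc(F)cc3)C/C(=C\c3cc(OC)cc(OC)c3)C2=O)cc(OC)c1`, which carries no 3-nitrophenyl, gives 19800 nM. Compound 3 `O=C1/C(=C/c2cccc([N+](=O)[O-])c2)CN(S(=O)(=O)c2ccc(F)cc2)C/C1=C\c1ccccc1F` gives 17000 nM, a value within the scatter of both others, so the three cannot be ranked.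

Compound 4 `COc1cc(/C=C2\CN(S(=O)(=O)c3ccc(F)cc3)C/C(=C\c3ccccc3F)C2=O)cc(OC)c1OC` has not yet been measured in this assay. It keeps the 2-fluorophenyl of compound 3 and differs from it by a single exchange: 3,4,5-trimethoxyphenyl in place of 3-nitrophenyl on a double-bonded chain carbon bound to a double-bonded ring carbon. This places 3,4,5-trimethoxyphenyl in place of 3-nitrophenyl on a double-bonded chain carbon bound to a double-bonded ring carbon.

Among the measured compounds shown here, no measured step covers this exchange directly. The closest one also removes a 3-nitrophenyl, with 2-fluorophenyl entering instead, and it is small: a 1.1-fold higher number from compound 1 to compound 3 (0.04 log units; within the scatter). With that step inside the scatter, no change beyond the scatter is expected here. The expected step is a 1.1-fold lower number from compound 3 to compound 4 (0.03 log units; within the scatter). For compound 4 the estimated value is 16000 nM, with an expected range of 8000 nM to 32000 nM.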

Compound 4, half-maximal inhibitory concentration: 17600 nM
Beside the measured number, compound 4's estimate is 1.1-fold (0.04 log units) below it; the range from low to high includes it.
By their numbers in this assay, from the lowest: compounds 1, 3, 4 and 2 (each within the scatter of the next).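

In this assay, among the compounds shown here, the first direct reading of this exchange, with the 2-fluorophenyl held constant, is a 1.0-fold higher number from compound 3 to compound 4 (0.02 log units; within the scatter). For the compounds shown here, until now, the only step at this place on a double-bonded chain carbon bound to a double-bonded ring carbon had brought in 2-fluorophenyl; this one shows that a 3,4,5-trimethoxyphenyl of 12 heavy atoms, replacing a 3-nitrophenyl of 9, also causes no change beyond the scatter. No measurement available here explains why the number stays flat.

All the groups shown at this place are aryl groups, so it remains open whether an amine, a carboxylic acid or a longer alkyl chain there would move the number beyond the scatter. The sulfonyl-bearing part of the shared core is also the same throughout, leaving the effect of any change there unknown.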